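This account rests on a few compounds, and the source may have more. Where it says the series, first, only, none or still open, it means among the compounds named here.

Of the compounds shown here, three built on one shared core have been measured in an ADME assay on isolated protein for inhibition of peroxidase (Raphanus sativus), read by fluorescence and Amplex Red, tested at 5 uM; a lower number here means a stronger effect, a higher number a weaker effect of the compound at the concentration tested. Compound 1 `Oc1ccc(NC(=S)Nc2ccc3[nH]ccc3c2)cc1` gives 41.5%, compound 2 `Oc1ccc(NC(=S)Nc2ccc3[nH]ccc3c2)cc1Cl` gives 39.9%, and compound 3 `COC(=O)c1cc(NC(=S)Nc2ccc3[nH]ccc3c2)ccc1O` gives 61.2%. Compound 2 has the lowest of the three numbers: compound 1 stands nearest, the step of a number 1.6 percentage points lower from compound 1 to compound 2 (within the scatter) lying within the scatter, while compound 3 stands furthest, the step of a number 21.3 percentage points higher from compound 2 to compound 3 (beyond the scatter) lying beyond it. Compound 4 `Oc1c(Cl)cc(NC(=S)Nc2ccc3[nH]ccc3c2)cc1Cl` differs from compound 2 in one place: chloro in place of hydrogen on an aromatic carbon. Within the data shown here, the one measured step of the same kind, a number 1.6 percentage points lower from compound 1 to compound 2 (within the scatter), stayed within the scatter, so the step of a number 1.9 percentage points lower from compound 2 to compound 4 (within the scatter) is expected to stay within the scatter as well. Compound 4 is therefore estimated at 38% in this assay, within a range from 26% to 52%.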

Compound 4, a percentage reported as activity, at one concentration (the size of the read-out at that concentration, not a potency): 48.7%
The estimate for compound 4 lay 10.7 percentage points below the measured number; low and high end bracket the measured number.
By their numbers in this assay, from the lowest: compounds 2, 1 and 4 (each within the scatter of the next); then compound 3.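

With a chloro already on the ring, a second chloro ortho to the hydroxy group gives a number 8.8 percentage points higher from compound 2 to compound 4 (within the scatter) in this assay, so this change again produces no readable shift. The earlier compounds shown here showed this only for a single chloro, whereas compound 4 shows that the same holds with a chloro group meta to the new one. No measurement here bears on the reason for this result. Going by these compounds, it remains open whether an amine or a methyl group on this carbon would shift the number beyond the scatter, as methoxycarbonyl did in compound 3. On these data alone, whether a methoxy group could replace the hydroxy group also remains open.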